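A few compounds are considered here, and "the series" means these few. Any claim that something is new, unique, unknown or untested is made for them only; others in the source may bear on it.

Measured in a functional assay on KB cells (Homo sapiens) for cytotoxicity, read by MTT assay, with a stated time of 72 h; a higher number here means that more compound is needed for the effect, a lower number that less compound is needed:
compound 1 `O=C1/C(=C\c2ccc(O)cc2)c2ccccc2N1c1c(Cl)cccc1Cl` gives 2 ug/mL
compound 2 `Cc1ccc2nc(Cl)c(/C=C3\C(=O)N(c4c(Cl)cccc4Cl)c4ccccc43)cc2c1C` gives 10 ug/mL
compound 3 `O=C1/C(=C\c2cccc(Oc3ccccc3)c2)c2ccccc2N1c1c(Cl)cccc1Cl` gives 5 ug/mL

Compound 1 stands at the lowest of the three numbers in this assay. Its nearest neighbour is compound 3, whose number lies higher by a margin beyond the scatter; compound 2 stands furthest off, also beyond the scatter. Among the compounds with values here, no two of the measured compounds differ in one place only, so no single step can be read off among them; their values show only that both compounds carrying something other than the 4-hydroxyphenyl of compound 1 at that place come out with higher numbers.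

Compound 4 `O=C1/C(=C\c2ccccc2[N+](=O)[O-])c2ccccc2N1c1c(Cl)cccc1Cl` has not yet been measured in this assay. It differs from compound 1 by 2-nitrophenyl in place of 4-hydroxyphenyl on a double-bonded chain carbon bound to a double-bonded ring carbon. Within the data shown here, with no measured step to lean on, the expectation rests on the spread seen so far: compound 3 gives 5 ug/mL and compound 2 gives 10 ug/mL, both higher than compound 1, so a moderate rise in the number, beyond the scatter but smaller than the gap to compound 2, is expected for compound 4. The estimated step is a 2.5-fold higher number from compound 1 to compound 4 (0.40 log units; beyond the scatter). For compound 4 the expected value in this assay is 5 ug/mL, with a range from 2 ug/mL to 15 ug/mL.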

Compound 4, concentration for half-maximal effect: 1 ug/mL
For compound 4 the middle estimate is 5.0-fold (0.70 log units) above the measured one; the whole stated range lies above it.
By their numbers in this assay, from the lowest: compounds 4 and 1 (each within the scatter of the next); then compounds 3 and 2 (each within the scatter of the next).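

In this assay, within the data shown here, the exchange of 4-hydroxyphenyl for 2-nitrophenyl on a double-bonded chain carbon bound to a double-bonded ring carbon gives a 2.0-fold lower number from compound 1 to compound 4 (0.30 log units; within the scatter) and is the first step at this position that can be read. Among these compounds, this place therefore accepts two quite different substituted phenyl groups with no change beyond the scatter, and the hydrogen-bond donor of 4-hydroxyphenyl, which has no counterpart on 2-nitrophenyl, is not needed in this pair for a number of this size. No measurement is available that would explain why the two compounds stand so close.

On these data alone, it remains open whether an unsubstituted phenyl, a 4-methoxyphenyl or a 4-aminophenyl at this place would also stay in this range, and so whether the hydroxy or the nitro group contributes anything to the number on its own. The rest of the core of compound 1 is the same in compound 4, so this step says nothing about the other parts of the structure.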